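Swapping an Indole for a Dimethylphenyl Group

The compounds below may be only part of what the source reports. "The series", "measured", "known", "first", "only" and "open" are said of these compounds alone.

Of the compounds shown here, three built on one shared core have been tested in a functional assay on MCF7 cells (Homo sapiens) for inhibition, read by CCK-8 assay, with a stated time of 48 h; a higher number here means a weaker inhibitor, a lower number a stronger inhibitor. Compound 1 `COc1cc(-c2ccnc3cc(-c4ccc(C)cc4)nn23)cc(OC)c1OC` gives 47 nM. Compound 2 `COc1ccc(-c2cc3nccc(-c4cc(OC)c(OC)c(OC)c4)n3n2)cc1F` gives 183 nM, and compound 3 `COc1cc(-c2ccnc3cc(-c4cn(C)c5ccccc45)nn23)cc(OC)c1OC` gives 95 nM. Among these three numbers compound 3 stands second highest; its nearest neighbour is compound 2, within the scatter, and its furthest is compound 1, reached by a step of a 2.0-fold higher number from compound 1 to compound 3 (0.31 log units; beyond the scatter).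

Compound 4 `COc1cc(-c2ccnc3cc(-c4ccc(C)c(C)c4)nn23)cc(OC)c1OC` is not yet measured and differs from compound 3 in one place: 3,4-dimethylphenyl in place of 1-methyl-1H-indol-3-yl on an aromatic carbon. The step that bears most on this change is a 2.0-fold higher number from compound 1 to compound 3 (0.31 log units; beyond the scatter), which put the indole in place of a plain six-membered ring of carbon only; compound 4 returns to a ring of that kind. For comparison, a 3.9-fold higher number from compound 1 to compound 2 (0.59 log units; beyond the scatter) shows another such ring raising the number modestly, while a 1.9-fold lower number from compound 2 to compound 3 (0.28 log units; within the scatter) stays within the scatter. Undoing the indole is therefore expected to reverse that earlier modest rise, giving an expected 1.7-fold lower number from compound 3 to compound 4 (0.24 log units; within the scatter). Compound 4 is estimated at 55 nM, with a range from 25 nM to 130 nM.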

Compound 4, half-maximal inhibitory concentration: 26 nM
Compound 4: the middle estimate sits 2.1-fold (0.33 log units) above what was measured; the range from low to high includes it.
By their numbers in this assay, from the lowest: compounds 4 and 1 (each within the scatter of the next); then compounds 3 and 2 (each within the scatter of the next).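

In this assay the step back to a ring of carbon only gives a 3.7-fold lower number from compound 3 to compound 4 (0.56 log units; beyond the scatter) and shows that 3,4-dimethylphenyl at this position is clearly preferred to 1-methyl-1H-indol-3-yl. Set against the 3-fluoro-4-methoxyphenyl group, it gives a 7.0-fold lower number from compound 2 to compound 4 (0.85 log units; beyond the scatter) and the widest step yet seen here, while the extra methyl on the ring of compound 1 gives a 1.8-fold lower number from compound 1 to compound 4 (0.26 log units; within the scatter) and so leaves compound 1 and compound 4 indistinguishable. No measurement available here explains these differences.

Every group shown at this position carries an aromatic ring, so the effect of an amine, a carboxylic acid or a longer alkyl chain there remains open. On these data alone, whether these steps hold in other cell lines also remains open.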